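Acyl piperazine series: cytotoxicity working notes

The source may hold more compounds than are shown below. What is called first, only, known or untested is meant among the compounds shown, and "the series" means these compounds.

compound 1: `CC(=O)N1CCN(c2nc(=O)c3cc(C(F)(F)F)cc([N+](=O)[O-])c3s2)CC1` — > 125000 nM
compound 2: `O=C(C1CCCC1)N1CCN(c2nc(=O)c3cc(C(F)(F)F)cc([N+](=O)[O-])c3s2)CC1` — 120000 nM

In an ADME assay on Vero cells (Chlorocebus sabaeus) for cytotoxicity, read by MTT assay, with a stated time of 72 h (on this read-out higher numbers stand for lower toxicity in this test and lower numbers for higher toxicity in this test), compound 1 gives > 125000 nM, which is a limit of the assay rather than a number (the limit of > 125000 nM in this assay, at which 1 of the 2 values shown sits). Compound 2 gives 120000 nM in this assay. For the measured compounds named here, the single measured step, an at least 1.0-fold lower number from compound 1 to compound 2 (0.01 log units; that floor lies within the scatter), is within the scatter. Compound 3 `CCC(=O)N1CCN(c2nc(=O)c3cc(C(F)(F)F)cc([N+](=O)[O-])c3s2)CC1` differs from compound 1 by methyl in place of hydrogen on a saturated chain carbon bound to a carbonyl carbon, at the same carbonyl-bound position that the step to compound 2 changed far more heavily. Going by the values given here, that step is the only guide, and it showed no movement; the expected step is a step that the limit leaves unreadable from compound 1 to compound 3, nothing beyond the scatter. Compound 3 is therefore estimated at 130000 nM, range 90000 nM to 200000 nM, with a fair chance that only a limit is reported.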

Compound 3, half-maximal cytotoxic concentration: > 125000 nM
Compound 3 gave a limit, no number; the forecaster's own chance of this, stated with the estimate: 50%; the middle value is on the limit's open side.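

Compound 3 gives only a limit of the assay in this assay, and the step from acetyl to propanoyl cannot be read. Ethyl in place of cyclopentyl on the carbonyl carbon gives an at least 1.0-fold higher number from compound 2 to compound 3 (0.01 log units; that floor lies within the scatter), so only a floor can be read for this change. At this position, neither the methyl of compound 1 nor the ethyl of compound 3 yields a number: the limit of > 125000 nM in this assay, at which 2 of the 3 values shown sit.

On these data alone, whether an amine or a carboxylic acid on this chain would yield a number in this assay remains open. So does the reading for a longer chain.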